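Moving the fluorine on the ring-bound phenyl of compound 3

A few compounds are considered here, and "the series" means these few. Any claim that something is new, unique, unknown or untested is made for them only; others in the source may bear on it.

Among the compounds measured so far in a functional assay on HOS-TE85 cells (Homo sapiens) for inhibition, read by CCK-8 assay, with a stated time of 72 h (a lower number here means a stronger inhibitor, a higher number a weaker inhibitor), compound 3 `O=C(NCCCCc1ccccc1)c1cccc(C2SCC(=O)N2c2cccc(F)c2)c1` gives the lowest number, 32.4 nM. Compound 1 `COc1ccc(F)cc1N1C(=O)CSC1c1cccc(C(=O)NCCCCn2cccn2)c1` gives 97.3 nM in this assay, a higher number than compound 3 by a gap that lies beyond the usual scatter. Compound 2 `COc1ccccc1N1C(=O)CSC1c1cc(F)cc(C(=O)O)c1` reaches only a limit of the assay, > 1000 nM in this assay, so no number is known for it; this is the limit (the limit of > 1000 nM in this assay, at which 1 of the 3 values shown sits).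

Compound 4 `O=C(NCCCCc1ccccc1)c1cccc(C2SCC(=O)N2c2ccccc2F)c1` has not been measured. It keeps every atom of compound 3 and differs only in the fluorophenyl on the amide-type nitrogen in the ring: 2-fluorophenyl in place of 3-fluorophenyl on an amide-type nitrogen in a ring. For the measured compounds named here, no measured pair in this set isolates such a change, so the expectation rests on compound 3 alone, with the step expected to stay within the usual scatter and to lean, if anywhere, toward a slightly higher number. Compound 4 is therefore estimated at 45 nM in this assay, within a range of 15 nM to 150 nM, which corresponds to an expected step of a 1.4-fold higher number from compound 3 to compound 4 (0.14 log units; within the scatter).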

Compound 4, half-maximal inhibitory concentration in the HOS-TE85 assay: 34.1 nM
Beside the measured number, compound 4's estimate is 1.3-fold (0.12 log units) above it, and the stated range covers the measured number.
By their numbers in the HOS-TE85 assay, from the lowest: compounds 3 and 4 (each within the scatter of the next); then compound 1. At a limit, above all of these: compound 2.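

For the compounds shown here, in the HOS-TE85 assay, 2-fluorophenyl in place of 3-fluorophenyl on the amide-type nitrogen in the ring gives a 1.1-fold higher number from compound 3 to compound 4 (0.02 log units; within the scatter), so this single change leaves the read-out within the scatter, which the earlier compounds, differing from one another in more than one place, could not show. In a physicochemical assay for solubility, read by turbidimetry, measured as kinetic solubility, at pH 6.8 (a higher number here means a more soluble compound, a lower number a less soluble compound), compound 3 gives 10000 nM and compound 4 gives 20000 nM, two values that also lie within the usual scatter of each other, so neither read-out separates this pair. The results shown include no measurement that bears on why the two compounds match.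

The compounds shown leave open whether the fluorine matters at all on this ring, as an unsubstituted phenyl would tell. They also leave open how far this position accepts a larger change, such as a chlorophenyl or a pyridine.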